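The compounds below may be only part of what the source reports. "The series", "measured", "known", "first", "only" and "open" are said of these compounds alone.

Measured so far:
- Compound 1, `CSc1ccc(CNc2nc(SC)nc3ncccc23)cc1`: 16800 nM
- Compound 2, `CCCCC[Se]c1nc(N)c2ccccc2n1`: 68000 nM
- Compound 3, `COc1ccc(CNc2nc([SeH])nc3ccccc23)cc1`: > 100000 nM

In a functional assay on CCRF-CEM cells (Homo sapiens) for cytotoxicity, read by MTT assay, with a stated time of 72 h (a higher number here means a weaker inhibitor of growth, a lower number a stronger inhibitor of growth), compound 1 gives 16800 nM, the lowest of the two numbers in hand. Compound 2 gives 68000 nM in this assay, a higher number that lies beyond the scatter of the method. Compound 3 reaches only a limit in this assay, > 100000 nM; this is the limit described as the limit of > 100000 nM in this assay, at which 1 of the 3 values shown sits, and it reports no number for compound 3.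

The next compound, compound 4, `COc1ccc(CNc2nc(SC)nc3ncccc23)cc1`, keeps the core of compound 1 and changes one group on the benzyl ring: methoxy in place of methylsulfanyl on an aromatic carbon. Both groups carry one hydrogen-bond acceptor and neither carries a donor, and the place on the aromatic carbon, para to a large group, is unchanged. Among the compounds with values here, no measured pair in this set shows the same swap on the same core, so the direction of the step cannot be read off any measured step.

Compound 4 is therefore expected to sit close to compound 1, with the step from compound 1 to compound 4 estimated at a 1.2-fold higher number from compound 1 to compound 4 (0.08 log units; within the scatter), no larger than the scatter of repeated measurements. The estimate for compound 4 in this assay is 20000 nM, with a range from 8000 nM to 60000 nM.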

Compound 4, concentration for total growth inhibition: > 100000 nM
Compound 4: only a limit was reported (the forecaster's own chance of this, stated with the estimate: 10%); middle value at least 5.0-fold (0.69 log units) from the limit.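

In this assay, methoxy in place of methylsulfanyl on an aromatic carbon, para to a large group, is the only change in one place among the compounds shown, and it gives an at least 5.9-fold higher number from compound 1 to compound 4 (0.77 log units; beyond the scatter). Compound 4 stands at > 100000 nM, which is a limit of the assay and not a number. As far as these compounds go, the two groups match in heavy atoms and in hydrogen-bond donors and acceptors, so these counts do not separate them, and the full size of the step stays unknown because the reading ends at a limit: the limit of > 100000 nM in this assay, at which 2 of the 4 values shown sit.

From the compounds shown here alone, one pair cannot tell whether this position depends on the sulfur of methylsulfanyl or whether the result is specific to methoxy, and the effect of a longer chain on the sulfur, such as ethylsulfanyl, or of a chlorine or a hydrogen at the same place remains open. Going by these compounds, whether methoxy in place of methylsulfanyl gives a step of the same direction on any other core also remains open.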